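Solubility notes: replacing 3-methylpiperidin-1-yl with isobutoxy

The compounds below may be only part of what the source reports. "The series", "measured", "known", "first", "only" and "open" are said of these compounds alone.

Values so far in a physicochemical assay for solubility; on this read-out lower numbers stand for lower solubility and higher numbers for higher solubility
- compound 1 `CC1CCCN(c2cc(C(F)(F)F)nn2-c2ccc(S(C)(=O)=O)cn2)C1` gives "not determined" (no result reported)
- compound 2 `CC1CCCN(c2c(C#N)c(C(F)(F)F)nn2-c2ccc(S(C)(=O)=O)cn2)C1` gives 100 ug/mL
- compound 3 `CC1CCCN(c2c(C#N)c(C(F)F)nn2-c2ccc(S(C)(=O)=O)cc2)C1` gives 50 ug/mL
- compound 4 `CC(C)COc1c(C#N)c(C(F)(F)F)nn1-c1ccc(S(C)(=O)=O)cn1` is still to be measured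

Going by the values given here, compound 2 (100 ug/mL) and compound 3 (50 ug/mL) hold the only two numbers, and these lie within the scatter of each other. Compound 4 has isobutoxy in place of the 3-methylpiperidin-1-yl of compound 2 on an aromatic carbon (isobutoxy in place of 3-methylpiperidin-1-yl on an aromatic carbon). Among the compounds with values here, no measured pair shows this change in this assay and the direction remains open. The estimated step of a 1.4-fold lower number from compound 2 to compound 4 (0.15 log units; within the scatter) is expected to stay within the scatter. Compound 4 is expected at 70 ug/mL with 25 ug/mL to 150 ug/mL as its estimated range.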

Compound 4, solubility: < 25 ug/mL
Compound 4 ended at the assay's limit; the forecaster's own chance of this, stated with the estimate: 20%; middle value at least 2.8-fold (0.44 log units) away from the limit.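

In this assay, the aromatic carbon bearing these groups proves sensitive to the substituent: isobutoxy in place of 3-methylpiperidin-1-yl gives an at least 4.0-fold lower number from compound 2 to compound 4 (0.60 log units; beyond the scatter). The earlier compounds shown here offered no measured pair for this change. The value of compound 4, < 25 ug/mL, is a limit of the assay and not a number: the limit of < 25 ug/mL in this assay, at which 1 of the 4 values shown sits.

This single pair cannot separate the loss of the ring from the exchange of nitrogen for oxygen. As far as these compounds go, how an open-chain amine such as diethylamino or a longer chain such as hexyloxy would read at this position remains open.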